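A few compounds are considered here, and "the series" means these few. Any claim that something is new, unique, unknown or untested is made for them only; others in the source may bear on it.

Values so far in a functional assay on HeLa cells (Homo sapiens) for inhibition, read by MTT assay, with a stated time of 48 h (on this read-out lower numbers stand for stronger inhibition and higher numbers for weaker inhibition), are these.

Compound 1 `O=C(CC(c1ccc(Cl)cc1)C(C(=O)Nc1ccccn1)C(=O)Nc1ccccn1)c1ccccc1` gives 13600 nM
Compound 2 `O=C(CC(c1ccc(F)cc1)C(C(=O)Nc1ccccn1)C(=O)Nc1ccccn1)c1ccc(F)cc1` gives 25500 nM
Compound 3 `O=C(CC(c1ccc(Cl)cc1)C(C(=O)Nc1ccccn1)C(=O)Nc1ccccn1)c1ccc(F)cc1` gives 4100 nM

Compound 3 has the lowest number of the three, beyond the scatter against both others. Compound 4 `O=C(CC(c1ccc(Cl)cc1)C(C(=O)Nc1ccccn1)C(=O)Nc1ccccn1)c1ccc2ccccc2c1` differs from it as follows: naphthalen-2-yl in place of 4-fluorophenyl on a carbonyl carbon. Among the compounds with values here, only one measured step touches this group: a 3.3-fold lower number from compound 1 to compound 3 (0.52 log units; beyond the scatter) for fluoro in place of hydrogen on an aromatic carbon. The step of a 6.2-fold lower number from compound 2 to compound 3 (0.79 log units; beyond the scatter) is a change elsewhere in the molecule and bears on this one only weakly. Naphthalen-2-yl carries no fluoro, so a small rise in this assay is expected, though no step beyond the scatter can be counted on. The estimated change is a 1.7-fold higher number from compound 3 to compound 4 (0.23 log units; within the scatter) for now. For compound 4 the estimate is 7000 nM with an expected range from 2300 nM to 21000 nM.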

Compound 4, half-maximal inhibitory concentration: "not active" (no number reported)
For compound 4 the study gives words and no number; the estimate stays without a comparison.
By their numbers in this assay, from the lowest: compound 3; then compounds 1 and 2 (each within the scatter of the next).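

Within the data shown here, compound 4 is reported in words only in this assay, so no step from compound 3 to compound 4 can be read. Nothing shown accounts for this result. Going by these compounds, how far naphthalen-2-yl in place of 4-fluorophenyl shifts the number stays open.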